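The source may hold more compounds than are shown below. What is called first, only, known or untested is meant among the compounds shown, and "the series" means these compounds.

Working notes on the series.

Of the compounds shown here, two have been measured. Compound 1 is `CCOc1ccc(-c2nc(NS(=O)(=O)c3ccc(OC)c(F)c3)sc2-c2cc(OC)c(OC)c(OC)c2)cc1` and compound 2 is `C=CCN(CC=C)c1nc(-c2ccc(OCC)cc2)c(-c2cc(OC)c(OC)c(OC)c2)s1`; both carry the same substituted core, and differ in the group on the ring carbon of that core. In a functional assay on SMMC-7221 cells (Homo sapiens) for antiproliferative activity, read by MTT assay, with a stated time of 48 h (on this read-out higher numbers stand for weaker inhibition and lower numbers for stronger inhibition), compound 1 gives only a limit of the assay, > 5000 nM, and not a number. In this assay compound 2 likewise gives only a limit, > 5000 nM, and not a number. Among the compounds with values here, compound 2 therefore stands at the limit, on a par with the only other value shown, and both values sit where the limit of > 5000 nM in this assay, at which 2 of the 2 values shown sit, places them, so no step between measured compounds can be stated.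

The next compound, compound 3, is `CCCN(CCC)c1nc(-c2ccc(OCC)cc2)c(-c2cc(OC)c(OC)c(OC)c2)s1`. It differs from compound 2 by dipropylamino in place of diallylamino on an aromatic carbon. The change exchanges the unsaturated chains of the diallylamino group for the saturated chains of the dipropylamino group, with the place on the core unchanged. Within the data shown here, with compound 2 at the limit and no measured step to draw on, a step from compound 2 to compound 3 of no more than the usual scatter is expected, in no stated direction. Compound 3 is estimated at 7000 nM, with a range of 3000 nM to 20000 nM, which corresponds to an expected step that the limit leaves unreadable from compound 2 to compound 3.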

Compound 3, half-maximal inhibitory concentration: > 5000 nM
Compound 3 gave a limit, no number; the forecaster's own chance of this, stated with the estimate: 75%; the middle value does not contradict the limit.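

In this assay, within the data shown here, compound 3 gives only a limit, > 5000 nM, and not a number, so with compound 2 also at a limit, no step between compound 2 and compound 3 can be read. All the values shown stand at one place: the limit of > 5000 nM in this assay, at which 3 of the 3 values shown sit.

The compounds shown leave open how dipropylamino and diallylamino compare, and what change on the shared core would give a measurable number.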